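This account rests on a few compounds, and the source may have more. Where it says the series, first, only, none or still open, it means among the compounds named here.

Measured compounds:
Compound 1, `COc1ccc(N(CC(=O)NCCC[Te]c2ccccc2)C(=O)CNC(=O)OC(C)(C)C)cc1`, gives 25000 nM in an ADME assay on cells (Fibroblast, Homo sapiens) for cytotoxicity, read by MTT assay, with a stated time of 24 h; on this read-out lower numbers stand for stronger inhibition and higher numbers for weaker inhibition.
Compound 2, `COc1ccc(N(CC(=O)NCCCSc2ccccc2)C(=O)CNC(=O)OC(C)(C)C)cc1`, gives >= 100000 nM in this assay, which is a limit of the assay.
Compound 3, `COc1ccc(N(CC(=O)NCCCSc2ccccc2)C(=O)c2ccccc2)cc1`, gives >= 100000 nM in this assay, likewise a limit of the assay.

Compound 1 and compound 2 differ by a group of 7 heavy atoms (6 carbon, 1 tellurium; one six-membered aromatic ring of carbon only) in place of a group of 7 heavy atoms (6 carbon, 1 sulfur; one six-membered aromatic ring of carbon only), on a saturated chain carbon, three bonds along the chain from an amide-type nitrogen, and the step is an at least 4.0-fold lower number from compound 2 to compound 1 (0.60 log units; beyond the scatter). Compound 2 and compound 3 differ in their cores by phenyl in place of ((tert-butoxycarbonyl)amino)methyl on a carbonyl carbon; the step that the two limits leave unreadable from compound 2 to compound 3 cannot be sized because of the limit of >= 100000 nM in this assay, at which 2 of the 3 values shown sit. Compound 4, `COc1ccc(N(CC(=O)NCCC[Te]c2ccccc2)C(=O)c2ccccc2)cc1`, is not yet measured in this assay. It differs from compound 3 by a group of 7 heavy atoms (6 carbon, 1 tellurium; one six-membered aromatic ring of carbon only) in place of a group of 7 heavy atoms (6 carbon, 1 sulfur; one six-membered aromatic ring of carbon only), on a saturated chain carbon, three bonds along the chain from an amide-type nitrogen, the same change that separates compound 2 from compound 1, at the same place. Compound 4 is expected to show a step of an at least 4.0-fold lower number from compound 3 to compound 4 (0.60 log units; beyond the scatter). That expectation rests on the step of an at least 4.0-fold lower number from compound 2 to compound 1 (0.60 log units; beyond the scatter). The value of compound 3 is only a limit of the assay. Compound 1, with its value of 25000 nM, therefore serves as the anchor for the expectation instead. Compound 4 is therefore estimated at 25000 nM in this assay, expected to fall between 8000 nM and 100000 nM.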

Compound 4, half-maximal inhibitory concentration: 7500 nM
Estimate against measurement, compound 4: 3.3-fold (0.52 log units) above, and the stated range ends above it.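

In this assay, putting the tellurium group in place of phenylsulfanyl lowers the number on both cores, so the direction of the change carries over across these two cores: the same change on two cores in this assay, an at least 4.0-fold lower number (0.60 log units; beyond the scatter) from compound 2 to compound 1 and an at least 13-fold lower number (1.12 log units; beyond the scatter) from compound 3 to compound 4; the limit leaves it open whether they differ. Compound 2 and compound 3 both sit at a limit of the assay, so neither step has a true size, and the data do not show whether the change counts for more on one core than on the other. The core change itself reads only on the tellurium compounds, as a 3.3-fold lower number from compound 1 to compound 4 (0.52 log units; beyond the scatter), and the matching step on the sulfur compounds cannot be read.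

The compounds shown leave open how a selenium atom in place of the tellurium would read. They also leave open whether the step survives on a longer chain, or on a core with a free amine in place of the tert-butoxycarbonyl-protected one.

The new step, an at least 13-fold lower number from compound 3 to compound 4 (1.12 log units; beyond the scatter), is itself only a bound.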